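Phenyl Swap on a Shorter Chain: Expected Potency

A few compounds are considered here, and "the series" means these few. Any claim that something is new, unique, unknown or untested is made for them only; others in the source may bear on it.

Measured compounds:
Compound 1 `CCCc1nc(-c2ccccc2)c(CNCCCN2CCN(c3cccc(F)c3)CC2)o1` gives 3030 nM
Compound 2 `CCCc1nc(-c2ccccc2)c(CNCCCN2CCN(c3ccc(C(F)(F)F)cc3)CC2)o1` gives 7250 nM
Compound 3 `CCCc1nc(-c2ccccc2)c(CNCCN2CCN(c3ccc(C(F)(F)F)cc3)CC2)o1` gives 1300 nM

All three were tested in an assay on HEK293 cells for inhibition of Voltage-dependent T-type calcium channel subunit alpha-1G (Homo sapiens), read by patch clamp; on this read-out higher numbers stand for weaker inhibition and lower numbers for stronger inhibition. Compounds 1 and 2 differ in a single place, (3-fluorophenyl in place of 4-(trifluoromethyl)phenyl on an amine nitrogen in a ring), and this change gave a 2.4-fold lower number from compound 2 to compound 1 (0.38 log units; beyond the scatter). Compound 3 differs from compound 2 in more than one place; the difference between the two cores is not broken down here. In this assay compound 3 stands lowest, with steps to both other compounds beyond the scatter, so it is the strongest inhibitor of the three.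

Compound 4 `CCCc1nc(-c2ccccc2)c(CNCCN2CCN(c3cccc(F)c3)CC2)o1` has not been measured. It differs from compound 3 by 3-fluorophenyl in place of 4-(trifluoromethyl)phenyl on an amine nitrogen in a ring, the same change, at the same place, as from compound 2 to compound 1. Because that earlier change gave a 2.4-fold lower number from compound 2 to compound 1 (0.38 log units; beyond the scatter), a step of similar size is expected here, a 2.2-fold lower number from compound 3 to compound 4 (0.34 log units; beyond the scatter), though the cores differ and the step may not carry over exactly. Compound 4 is therefore estimated at 600 nM, expected to lie between 250 nM and 1400 nM.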

Compound 4, half-maximal inhibitory concentration: 3350 nM
Beside the measured number, compound 4's estimate is 5.6-fold (0.75 log units) below it; measured number above the stated range.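

In this assay, putting 3-fluorophenyl in place of 4-(trifluoromethyl)phenyl on the core of compound 3 gave a 2.6-fold higher number from compound 3 to compound 4 (0.41 log units; beyond the scatter), so the number rose here, whereas the same swap had lowered it on the core of compound 2. The two steps run in opposite directions, and the gap between them is larger than repeated measurements would normally explain: the same change on two cores in this assay, a 2.4-fold lower number (0.38 log units; beyond the scatter) from compound 2 to compound 1 and a 2.6-fold higher number (0.41 log units; beyond the scatter) from compound 3 to compound 4, 6.2-fold (0.79 log units) apart, beyond the scatter of two such steps. The effect of this change therefore cannot simply be carried from one core to the other in this series, although these two pairs do not show why the cores respond differently or how any other change would behave.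

Within the data shown here, with only two pairs, it remains open whether this reversal is particular to these two phenyl groups or would also appear with others. An unsubstituted phenyl or a chlorophenyl on the same ring nitrogen, or a longer chain in the core, could help to settle that question.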